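Ring size of the aryl amine on the benzylamide core

A few compounds are considered here, and "the series" means these few. Any claim that something is new, unique, unknown or untested is made for them only; others in the source may bear on it.

Measured compounds in an assay on CHO cells for antagonist activity at transient receptor potential cation channel subfamily V member 1 (Homo sapiens), read by FLIPR; a lower number here means a stronger inhibitor, a higher number a weaker inhibitor:
compound 1 `CCCCN(C)c1cc(C(F)(F)F)ccc1CNC(=O)C(C)c1ccc(NS(C)(=O)=O)c(F)c1` gives 1.2 nM
compound 2 `CCCN(CCC)c1cc(C(F)(F)F)ccc1CNC(=O)C(C)c1ccc(NS(C)(=O)=O)c(F)c1` gives 0.3 nM
compound 3 `CC(C(=O)NCc1ccc(C(F)(F)F)cc1N1CCCC1)c1ccc(NS(C)(=O)=O)c(F)c1` gives 2.3 nM

Compound 3 carries the highest of the three numbers in this assay, yet the gap a 1.9-fold higher number from compound 1 to compound 3 (0.28 log units; within the scatter) lies within the scatter, so only compound 2 stands clearly apart from it: a 7.7-fold higher number from compound 2 to compound 3 (0.88 log units; beyond the scatter).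

Compound 4 `CC(C(=O)NCc1ccc(C(F)(F)F)cc1N1CCCCCC1)c1ccc(NS(C)(=O)=O)c(F)c1` differs from compound 3 in one place: azepan-1-yl in place of pyrrolidin-1-yl on an aromatic carbon.

Going by the values given here, no measured step changes a ring in the same way, so the acyclic pairs are the nearest guide. There, a 4.0-fold lower number from compound 1 to compound 2 (0.60 log units; beyond the scatter) shows that the amine bearing more heavy atoms gave the lower number, and compound 2, whose dipropylamino group matches the heavy-atom count of azepan-1-yl, holds the lowest number of the set. The step from compound 3 to compound 4 is therefore expected to lower the number, by an amount of the order of a 3.3-fold lower number from compound 3 to compound 4 (0.52 log units; beyond the scatter), though it could also stay within the scatter.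

On that basis compound 4 is estimated at 0.7 nM in this assay, with a likely range from 0.2 nM to 2.5 nM.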

Compound 4, inhibition constant: 1.6 nM
For compound 4 the middle estimate is 2.3-fold (0.36 log units) below the measured one; low and high end bracket the measured number.
By their numbers in this assay, from the lowest: compound 2; then compounds 1, 4 and 3 (each within the scatter of the next).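

Widening the ring from five-membered to seven-membered, on an aromatic carbon ortho to a large group, does not separate the two amines in this assay: a 1.4-fold lower number from compound 3 to compound 4 (0.16 log units; within the scatter). Azepan-1-yl also cannot be told apart from the open-chain butyl(methyl)amino group, a 1.3-fold higher number from compound 1 to compound 4 (0.12 log units; within the scatter), but it stands clearly apart from dipropylamino, a 5.3-fold higher number from compound 2 to compound 4 (0.73 log units; beyond the scatter), so the seven-membered ring does not reproduce the low number of compound 2 and heavy-atom count alone does not account for these four compounds, with compound 4 as the case against that reading. No measurement bears on what lies behind this gap between the ring and the open chain.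

As far as these compounds go, how piperidin-1-yl, or a morpholin-4-yl ring carrying an oxygen atom, would read at this position remains open, as does whether a longer open chain such as dibutylamino would stay close to compound 2. From the compounds shown here alone, all four compounds also keep the trifluoromethyl group and the shared core, so whether the gap between dipropylamino and azepan-1-yl persists with another group in place of trifluoromethyl is equally open.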